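The source may hold more compounds than are shown below. What is called first, only, known or untested is meant among the compounds shown, and "the series" means these compounds.

In a functional assay on PC-3 cells (Homo sapiens) for inhibition, read by MTT assay, with a stated time of 72 h (on this read-out higher numbers stand for weaker inhibition and lower numbers for stronger inhibition), compound 1 (`FC(F)(F)c1ccc(CSc2nc(Sc3ccccn3)cc(C(F)(F)F)n2)cc1`) gives 25200 nM and compound 2 (`FC(F)(F)c1ccc(CSc2nc(SC3=NCCS3)cc(C(F)(F)F)n2)cc1`) gives 40600 nM. For the measured compounds named here, these are the only two numbers available, and compound 2 lies within the scatter of compound 1, so the two stand level. Compound 3 (`FC(F)(F)c1ccc(CSc2nc(Sc3ncc(-c4ccncc4)s3)cc(C(F)(F)F)n2)cc1`) keeps the shared core and changes the group on the sulfur: a group of 11 heavy atoms (8 carbon, 2 nitrogen, 1 sulfur; one five-membered aromatic ring with 2 hetero atoms, one six-membered aromatic ring with 1 hetero atom) in place of a group of 5 heavy atoms (3 carbon, 1 nitrogen, 1 sulfur; one five-membered non-aromatic ring with 2 hetero atoms), on a sulfur. The 5-(pyridin-4-yl)-1,3-thiazol-2-yl group thus brings one five-membered aromatic ring with 2 hetero atoms and one six-membered aromatic ring with 1 hetero atom where one five-membered non-aromatic ring stood. Going by the values given here, only one measured step bears on this, an exchange on the same sulfur, a 1.6-fold higher number from compound 1 to compound 2 (0.21 log units; within the scatter). Among the compounds with values here, that step was small, but no measured compound carries a group with two rings there, so the expectation in this assay is loose: no change beyond the scatter and no firm direction. The expected step is a 1.4-fold lower number from compound 2 to compound 3 (0.13 log units; within the scatter). For compound 3 the estimated value is 30000 nM, with an expected range from 10000 nM to 70000 nM.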

Compound 3, half-maximal inhibitory concentration: 7350 nM
Estimate against measurement, compound 3: 4.1-fold (0.61 log units) above; measured number below the stated range.
By their numbers in this assay, from the lowest: compound 3; then compounds 1 and 2 (each within the scatter of the next).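

In this assay, the 5-(pyridin-4-yl)-1,3-thiazol-2-yl group on this sulfur gives a 5.5-fold lower number from compound 2 to compound 3 (0.74 log units; beyond the scatter), and in place of pyridin-2-yl it gives a 3.4-fold lower number from compound 1 to compound 3 (0.54 log units; beyond the scatter); both steps lie beyond the scatter, whereas the earlier exchange on the same sulfur did not. For the compounds shown here, this is the first sign that the number can move with the group at this place, and it moved toward stronger inhibition with a group holding a five-membered aromatic ring and a six-membered aromatic ring. Nothing measured here explains why the number fell.

The compounds shown leave open which part of the entering group carries the step, since the 1,3-thiazol-2-yl and pyridin-4-yl parts arrive together, and a plain 1,3-thiazol-2-yl group on the sulfur would separate them. Also open, from the compounds shown here alone, is whether a 5-phenyl-1,3-thiazol-2-yl group, which has a phenyl in place of the pyridin-4-yl part, would keep the lower number, or whether a group bearing an amine or a carboxylic acid there would do so.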